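Shortening the benzyl arm: from compound 2 to compound 3

This account rests on a few compounds, and the source may have more. Where it says the series, first, only, none or still open, it means among the compounds named here.

Compound 1 `CCCC(CO)NCc1nc2c(OCC3CCCCC3)cccc2[nH]1` and compound 2 `c1ccc(CNCc2nc3c(OCC4CCCCC4)cccc3[nH]2)cc1` share one core and differ only at an amine nitrogen. In an assay on cells for inhibition of interleukin-5 receptor subunit alpha (Mus musculus), read by WST assay, with a stated time of 48 h, in the presence of a further agent that is not named here (on this read-out higher numbers stand for weaker inhibition and lower numbers for stronger inhibition), compound 1 gives 7500 nM. For compound 2 this assay reports only a limit, > 30000 nM, so its standing rests on the limit of > 30000 nM in this assay, at which 1 of the 2 values shown sits, rather than on a number. For the measured compounds named here, the single measured step, an at least 4.0-fold higher number from compound 1 to compound 2 (0.60 log units; beyond the scatter), shows that the benzyl group weakens inhibition relative to the 1-(hydroxymethyl)butyl group.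

Compound 3 `c1ccc(NCc2nc3c(OCC4CCCCC4)cccc3[nH]2)cc1` carries the change one bond further: phenyl in place of benzyl on an amine nitrogen. Going by the values given here, no measured step covers the replacement of benzyl by phenyl on this nitrogen, so the expectation leans on the position of compound 2 alone. Because compound 2 already sits at the limit > 30000 nM, the expected step of a number no higher from compound 2 to compound 3 (the limit leaves the size open) amounts to no resolvable change in this assay. Compound 3 is therefore estimated at 30000 nM, within 10000 nM to 100000 nM, with a fair chance that this assay again returns only a limit rather than a number.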

Compound 3, half-maximal inhibitory concentration: > 30000 nM
Compound 3 ended at the assay's limit; the forecaster's own chance of this, stated with the estimate: 60%; the middle value sits exactly at the limit.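

In this assay compound 3 gives > 30000 nM, which is a limit and not a number. Set against the 1-(hydroxymethyl)butyl group, phenyl gives an at least 4.0-fold higher number from compound 1 to compound 3 (0.60 log units; beyond the scatter), so removing the carbon that separates the ring from the amine nitrogen does not bring back a measurable number: neither benzyl nor phenyl on this nitrogen yields one, and the 1-(hydroxymethyl)butyl group remains the only group shown here that does. The step from compound 2 to compound 3 cannot be read, so benzyl and phenyl cannot be ranked against each other, and this position now has most of its shown values at one ceiling: the limit of > 30000 nM in this assay, at which 2 of the 3 values shown sit.

The compounds shown leave open which part of the 1-(hydroxymethyl)butyl group goes with the number of compound 1, for instance whether a plain butyl chain or a shorter hydroxyethyl chain on the same nitrogen would give a value in the same range. Also open, on these data alone, is whether a phenyl ring carrying a carboxylic acid or an amine would bring an aromatic group on this nitrogen back from the limit to a number.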